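The compounds below may be only part of what the source reports. "The series", "measured", "known", "first", "only" and "open" are said of these compounds alone.

Compound 3 `C[C@H](NC(=O)c1cc2ccccc2cn1)C(=O)OCc1ccccc1` has the highest of the three numbers measured in a functional assay on the whole organism (CCRF S-180 cells, Mus musculus) for inhibition, in a xenograft, with stated times of 7 days and 24 h, at a dose of 100 umol/kg by the intraperitoneal route; on this read-out higher numbers stand for more inhibition at the one dose given (going by the name of the read-out) and lower numbers for less inhibition: compound 3 gives 40.6%. Compound 2 `CSCC[C@H](NC(=O)c1cc2ccccc2cn1)C(=O)OCc1ccccc1` gives 39.6%, and a number 1 percentage points higher from compound 2 to compound 3 (within the scatter). Compound 1 `NC(=O)CC[C@H](NC(=O)c1cc2ccccc2cn1)C(=O)OCc1ccccc1` gives 11.9%, and a number 28.7 percentage points higher from compound 1 to compound 3 (beyond the scatter). Compound 4 `CC[C@@H](C)[C@H](NC(=O)c1cc2ccccc2cn1)C(=O)OCc1ccccc1` has not yet been measured; it differs from compound 3 in one place: sec-butyl in place of methyl on a saturated chain carbon bound to an amide-type nitrogen and a carbonyl carbon.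

For the measured compounds named here, no measured step adds a carbon chain of this kind at this position, so the expectation rests on the two steps ending at compound 3. The step of a number 28.7 percentage points higher from compound 1 to compound 3 (beyond the scatter) removed a group carrying a hydrogen-bond donor and acceptor, whereas the step of a number 1 percentage points higher from compound 2 to compound 3 (within the scatter) removed a chain carrying no donor or acceptor and stayed within the scatter. Since the group entering compound 4 likewise carries no donor or acceptor, compound 4 is expected to sit close to compound 3, with the step of a number 0.6 percentage points lower from compound 3 to compound 4 (within the scatter) expected to stay within the scatter. Compound 4 is therefore estimated at 40%, within a range from 25% to 55%.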

Compound 4, a percentage reported as inhibition, in the whole organism at one dose (the size of the read-out at that dose, not a potency): 20.9%
Compound 4: the middle estimate sits 19.1 percentage points above what was measured; measured number below the stated range.
By their numbers in this assay, from the lowest: compounds 1 and 4 (each within the scatter of the next); then compounds 2 and 3 (each within the scatter of the next).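

In this assay, this position, the saturated chain carbon bound to an amide-type nitrogen and a carbonyl carbon, proves sensitive even to a group with no hydrogen-bond donor or acceptor: sec-butyl in place of methyl gives a number 19.7 percentage points lower from compound 3 to compound 4 (beyond the scatter), and sec-butyl in place of 2-(methylsulfanyl)ethyl gives a number 18.7 percentage points lower from compound 2 to compound 4 (beyond the scatter). Lacking donors and acceptors is therefore not enough to keep the number at the level of compound 2 and compound 3. Sec-butyl in place of 2-carbamoylethyl gives a number 9 percentage points higher from compound 1 to compound 4 (within the scatter), so two very different groups leave the read-out level here.

Nothing available explains the effect of sec-butyl at this position. As far as these compounds go, whether an unbranched butyl chain, an amine or a carboxylic acid at this place would read like compound 3 or like compound 4 remains open.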